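A few compounds are considered here, and "the series" means these few. Any claim that something is new, unique, unknown or untested is made for them only; others in the source may bear on it.

Measured compounds:

Compound 1 `O=C(N/N=C/c1ccc(F)cc1)c1ccc(O[C@@H]2O[C@H](CO)[C@@H](O)[C@H](O)[C@H]2O)cc1` gives 9.91% in a functional assay on MDA-MB-231 cells (Homo sapiens) for inhibition, read by MTT assay, with a stated time of 24 h, tested at 100 uM; on this read-out lower numbers stand for less inhibition and higher numbers for more inhibition at the one concentration tested (going by the name of the read-out).
Compound 2 `O=C(N/N=C/c1cccc([N+](=O)[O-])c1)c1ccc(O[C@@H]2O[C@H](CO)[C@@H](O)[C@H](O)[C@H]2O)cc1` gives 6.23% in this assay.
Compound 3 `Cc1ccc(/C=N/NC(=O)c2ccc(O[C@@H]3O[C@H](CO)[C@@H](O)[C@H](O)[C@H]3O)cc2)cc1` gives 9.28% in this assay.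

Compound 3 stands second highest of the three numbers, all of which are low. Its nearest neighbour is compound 1, with a number 0.6 percentage points lower from compound 1 to compound 3 (within the scatter); its furthest is compound 2, with a number 3.1 percentage points higher from compound 2 to compound 3 (within the scatter). Both gaps lie within the scatter, so the three compounds are not told apart on this read-out.

Compound 4 `CC(C)/C=N/NC(=O)c1ccc(O[C@@H]2O[C@H](CO)[C@@H](O)[C@H](O)[C@H]2O)cc1` has not yet been measured. It differs from compound 3 in one place: isopropyl in place of 4-methylphenyl on a carbon with a double bond to nitrogen.

Within the data shown here, two measured steps bear on this change, since both alter the group on the carbon with a double bond to nitrogen: a number 3.7 percentage points lower from compound 1 to compound 2 (within the scatter) and a number 3.1 percentage points higher from compound 2 to compound 3 (within the scatter). Both are within the scatter. Neither, however, replaces the six-membered aromatic ring with a group that has no ring, so the step to compound 4 goes beyond what the measured pairs cover. With every measured number sitting low and no step beyond the scatter among them, no step beyond the scatter in this assay is expected for compound 4.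

Compound 4 is therefore estimated at 7.5%, within 0% to 18%, which means an expected step of a number 1.8 percentage points lower from compound 3 to compound 4 (within the scatter).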

Compound 4, a percentage reported as inhibition, at one concentration (the size of the read-out at that concentration, not a potency): 1.7%
Estimate against measurement, compound 4: 5.8 percentage points above; low and high end bracket the measured number.
By their numbers in this assay, from the lowest: compounds 4, 2, 3 and 1 (each within the scatter of the next).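

In this assay, among these compounds, the carbon with a double bond to nitrogen now carries a group with no ring, where the earlier compounds all carried a six-membered aromatic ring of carbon only. Steps of a number 7.6 percentage points lower from compound 3 to compound 4 (within the scatter) and of a number 4.5 percentage points lower from compound 2 to compound 4 (within the scatter) and of a number 8.2 percentage points lower from compound 1 to compound 4 (within the scatter) all stay within the scatter, so on this read-out isopropyl is not told apart from 4-methylphenyl, 3-nitrophenyl or 4-fluorophenyl, even though the change from 4-methylphenyl removes the ring and goes from 7 heavy atoms to 3. No measurement at hand offers an explanation for these numbers.

Going by these compounds, all four numbers are low at the one concentration tested, so it stays open whether the group at this place has any bearing on the read-out at all. On these data alone, it also stays open whether an amine, a carboxylic acid or a longer chain on the carbon with a double bond to nitrogen would give a number beyond the scatter of these four compounds.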